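Ester to acid on the amide arm of compound 3

The source may hold more compounds than are shown below. What is called first, only, known or untested is meant among the compounds shown, and "the series" means these compounds.

Of the compounds shown here, three have been tested in a functional assay on MCF7 cells (Homo sapiens) for antiproliferative activity, read by MTT assay, with a stated time of 72 h (on this read-out higher numbers stand for weaker inhibition and lower numbers for stronger inhibition), and only one of them gives a number. Compound 1 `CCn1c(C(=O)NCCC(=O)OC)ccc1C(CC)(CC)c1ccc(C#CC(O)(CC)CC)c(C)c1` reaches only the limit of the assay, > 50000 nM, and so gives no number. Compound 2 `CCn1c(C(=O)On2nnc3ccccc32)ccc1C(CC)(CC)c1ccc(C#CC(O)(CC)CC)c(C)c1` likewise sits at the limit, > 50000 nM. Among the measured compounds shown here, the single change between them, a step that the two limits leave unreadable from compound 1 to compound 2, therefore cannot be read, because both ends rest at the limit of > 50000 nM in this assay, at which 2 of the 3 values shown sit. For the measured compounds named here, compound 3 `CCn1cc(C(CC)(CC)c2ccc(C#CC(O)(CC)CC)c(C)c2)cc1C(=O)NCC(=O)OC` is the one compound with a measured value: in this assay compound 3 gives 26500 nM. It stands alone, since the two other results give no number.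

Compound 4 `CCn1cc(C(CC)(CC)c2ccc(C#CC(O)(CC)CC)c(C)c2)cc1C(=O)N[C@@H](C(=O)O)C(C)C` differs from compound 3 in a single spot: 1-carboxy-2-methylpropyl in place of (methoxycarbonyl)methyl on an amide-type nitrogen. Going by the values given here, no measured step touches this position or this kind of exchange, so no measured step bears on it; the one step between compounds 1 and 2 concerns a different place and is unreadable anyway. With nothing to build on, the step from compound 3 to compound 4 is expected to stay within the scatter, a 1.1-fold higher number from compound 3 to compound 4 (0.05 log units; within the scatter), with the outcome open in either direction. Compound 4 is therefore estimated at 30000 nM, within a range from 8000 nM to 100000 nM, and it may well return only a limit.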

Compound 4, half-maximal inhibitory concentration: 18000 nM
Compound 4: the middle estimate sits 1.7-fold (0.22 log units) above what was measured, and the stated range covers the measured number.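

In this assay, the series now has its first readable step, a 1.5-fold lower number from compound 3 to compound 4 (0.17 log units; within the scatter), so exchanging (methoxycarbonyl)methyl for 1-carboxy-2-methylpropyl on the amide-type nitrogen leaves the reading within the scatter. This position can therefore carry a larger group with a free carboxylic acid, a hydrogen-bond donor and a defined stereocentre in place of the methyl ester, and compound 4 still gives a number, 18000 nM, rather than a limit. The exchange alters the chain and its end group at once, the step does not tell these two changes apart, and nothing measured here explains the result.

The compounds shown leave open what this arm would give with the carboxylic acid on the unbranched chain, or with the branched chain and the methyl ester kept. They also leave open whether an amine or a longer chain in the same place would move the reading beyond the scatter, in either direction.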